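Cytotoxicity notes: carbamoyl to acetyl on the triazole chain

The source may hold more compounds than are shown below. What is called first, only, known or untested is meant among the compounds shown, and "the series" means these compounds.

Measured compounds:
compound 1 `Cc1cc(C)c(Oc2cc(Nc3ccc(C#N)cc3)ncc2C(=O)NCc2cn(Cc3ccccc3F)nn2)c(C)c1` — > 222000 nM (a limit)
compound 2 `Cc1cc(C)c(Oc2cc(Nc3ccc(C#N)cc3)ncc2C(=O)NCc2cn(CC(N)=O)nn2)c(C)c1` — 24000 nM

In an ADME assay on MT4 cells (Homo sapiens) for cytotoxicity, read by MTT assay, with a stated time of 5 days (on this read-out higher numbers stand for lower toxicity in this test and lower numbers for higher toxicity in this test), compound 1 gives only a limit, > 222000 nM. Compound 2 gives 24000 nM in this assay, the only actual number shown. Among the measured compounds shown here, the only measured step is an at least 9.2-fold lower number from compound 1 to compound 2 (0.96 log units; beyond the scatter), and because of the limit of > 222000 nM in this assay, at which 1 of the 2 values shown sits, its true size is known only as a lower bound. Compound 3 `CC(=O)Cn1cc(CNC(=O)c2cnc(Nc3ccc(C#N)cc3)cc2Oc2c(C)cc(C)cc2C)nn1` differs from compound 2 by methyl in place of amino on a carbonyl carbon. For the measured compounds named here, this change is at a different site from the one measured step, so no measured step bears on it directly; it neither restores the 2-fluorophenyl nor removes the chain. Little movement beyond the scatter is expected, with a slight rise as the more likely direction. Compound 3 is estimated at 35000 nM in this assay, with a range of 12000 nM to 110000 nM. The expected step is a 1.5-fold higher number from compound 2 to compound 3 (0.16 log units; within the scatter).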

Compound 3, half-maximal cytotoxic concentration: 19400 nM
Estimate against measurement, compound 3: 1.8-fold (0.26 log units) above; low and high end bracket the measured number.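

In this assay, methyl in place of amino on a carbonyl carbon gives a 1.2-fold lower number from compound 2 to compound 3 (0.09 log units; within the scatter), so at this position the amino group and its hydrogen-bond donor can go with no change that stands out from the scatter. Acetyl in place of 2-fluorophenyl gives an at least 11-fold lower number from compound 1 to compound 3 (1.05 log units; beyond the scatter), so the lower number seen with carbamoyl also appears with a second carbonyl group on the same chain carbon, a pattern that rests on compound 2 and compound 3 alone. The size of that step is known only as a lower bound because one value is a limit: the limit of > 222000 nM in this assay, at which 1 of the 3 values shown sits.

Open, going by these compounds, is whether the carbonyl itself goes with the lower number, which a 2-hydroxypropyl group at the same place would address. Also open, on these data alone, is how a carboxylic acid, or a longer chain carrying the acetyl, would compare with compound 3.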